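Ring size in the lower side chain: compound 4

The source may report more compounds than this note shows. Statements on the series, on what has been measured and on what is new or still open speak of the compounds shown alone.

Compound 1 `COC(=O)CC/C=C\CC[C@H]1C(=O)C[C@@H](O)[C@@H]1/C=C/CC(C)(O)CCC1CCCC1` gives the highest number of the three measured in a functional assay on the whole organism with Rattus norvegicus as the target (a lower number here means that less compound is needed, a higher number that more compound is needed for the effect), at 1.31 mg/kg. Compound 2 `COC(=O)CC/C=C\CC[C@H]1C(=O)C[C@@H](O)[C@@H]1/C=C/CC(C)(O)CCC1CC1` gives 0.273 mg/kg, and compound 3 `COC(=O)CC/C=C\CC[C@H]1C(=O)C[C@@H](O)[C@@H]1/C=C/C[C@@](C)(O)/C=C/C1CC1` gives 0.402 mg/kg. The steps of a 4.8-fold lower number from compound 1 to compound 2 (0.68 log units; beyond the scatter) and a 3.3-fold lower number from compound 1 to compound 3 (0.51 log units; beyond the scatter) both lower the number, while the step of a 1.5-fold higher number from compound 2 to compound 3 (0.17 log units; within the scatter) shows that the added double bond in the chain changes little.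

Compound 4 `COC(=O)CC/C=C\CC[C@H]1C(=O)C[C@@H](O)[C@@H]1/C=C/C[C@@](C)(O)/C=C/C1CCC1` differs from compound 1 by 3-cyclobutyl-1-hydroxy-1-methylprop-2-en-1-yl in place of 3-cyclopentyl-1-hydroxy-1-methylpropyl on a saturated chain carbon bound to a double-bonded chain carbon. Its four-membered ring is smaller than the ring of compound 1 and larger than that of compounds 2 and 3, so a lowering is expected, probably less than in a 4.8-fold lower number from compound 1 to compound 2 (0.68 log units; beyond the scatter). Compound 4 is estimated at 0.6 mg/kg, range 0.3 mg/kg to 1.3 mg/kg, an expected step of a 2.2-fold lower number from compound 1 to compound 4 (0.34 log units; beyond the scatter).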

Compound 4, dose for half-maximal effect: 0.53 mg/kg
Compound 4: the middle estimate sits 1.1-fold (0.05 log units) above what was measured; the measured number falls inside the stated range.
By their numbers in this assay, from the lowest: compounds 2, 3 and 4 (each within the scatter of the next); then compound 1.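

In this assay a four-membered ring also gives a number beyond the scatter of the cyclopentyl compound, with a 2.5-fold lower number from compound 1 to compound 4 (0.39 log units; beyond the scatter). Cyclobutyl and cyclopropyl on the double-bonded chain carbon are not separated by a 1.3-fold higher number from compound 3 to compound 4 (0.12 log units; within the scatter), and a 1.9-fold higher number from compound 2 to compound 4 (0.29 log units; within the scatter) also stays within the scatter. No measured evidence bears on this result.

As far as these compounds go, compound 4 differs from compound 1 in both ring size and the chain double bond, so the share of each remains open. From the compounds shown here alone, how a cyclohexyl or phenyl ring would behave in this side chain also remains open.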